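Substituting the Sulfonamide Nitrogen of Compound 2

The compounds below may be only part of what the source reports. "The series", "measured", "known", "first", "only" and "open" are said of these compounds alone.

Measured so far in a physicochemical assay for lipophilicity, at pH 7.4; a lower number here means a more polar compound, a higher number a more lipophilic compound:
- compound 1 `CCc1ccc(N(CC2CC2)S(=O)(=O)c2ccc3c(c2)C(=O)CC(C2CCOCC2)O3)cc1`: 3.77
- compound 2 `CCc1ccc(NS(=O)(=O)c2ccc3c(c2)C(=O)CC(C2CCOCC2)O3)cc1`: 2.67

Of these two, compound 2, at 2.67, has the lower number, and its hydrogen-bearing sulfonamide nitrogen is the point of change. Compound 3 `CCc1ccc(N(C2COC2)S(=O)(=O)c2ccc3c(c2)C(=O)CC(C2CCOCC2)O3)cc1` differs from it by oxetan-3-yl in place of hydrogen on a sulfonamide nitrogen. Going by the values given here, only one measured step bears on this change: a number 1.10 log units lower from compound 1 to compound 2 (beyond the scatter), a large step, with hydrogen in place of cyclopropylmethyl on that same nitrogen. That step involves a different group and runs the opposite way, so it offers only a rough guide. No measurement for oxetan-3-yl exists yet. A modest rise in this assay is expected, well short of the measured step, and the estimated change is a number 0.23 log units higher from compound 2 to compound 3 (within the scatter). For compound 3 the estimated value is 2.9, with an expected range from 2.5 to 3.3.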

Compound 3, distribution coefficient: 2.72
Beside the measured number, compound 3's estimate is 0.18 log units above it; the measured number falls inside the stated range.
By their numbers in this assay, from the lowest: compounds 2 and 3 (each within the scatter of the next); then compound 1.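

In this assay a substituent on the sulfonamide nitrogen need not move the number: oxetan-3-yl in place of hydrogen gives a number 0.05 log units higher from compound 2 to compound 3 (within the scatter) even though it brings 4 heavy atoms. Among these three compounds, the identity of the group on that nitrogen matters more than whether a group is present at all, as oxetan-3-yl in place of cyclopropylmethyl gives a number 1.05 log units lower from compound 1 to compound 3 (beyond the scatter) on the same atom. Nothing available explains this difference between the two groups.

Cyclobutyl on the same nitrogen would show whether a four-membered ring without the ring oxygen stays level with compound 2 or comes closer to compound 1. On these data alone, a plain methyl, a longer alkyl chain or a ring bearing an amine remains open at this position too.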